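The source may report more compounds than this note shows. Statements on the series, on what has been measured and on what is new or still open speak of the compounds shown alone.

Compound 1 `COC(=O)C1=C(C)NC(C)=C(C(=O)OCc2ccccc2)C1c1csc(-c2ccc(Cl)cc2)n1` carries two ester groups on a shared core; in an assay on isolated protein for antagonist activity at Voltage-dependent L-type calcium channel subunit alpha-1C (Cavia porcellus), with a stated time of 15 min (on this read-out higher numbers stand for weaker inhibition and lower numbers for stronger inhibition), compound 1 gives 64900 nM. Compound 2 `CCOC(=O)C1=C(C)NC(C)=C(C(=O)OCc2ccccc2)C1c1csc(-c2ccc(Cl)cc2)n1` differs from it by methyl in place of hydrogen on a saturated chain carbon bound to an oxygen next to a carbonyl group, and in this assay compound 2 gives 3290 nM, which is a 20-fold lower number from compound 1 to compound 2 (1.30 log units; beyond the scatter). Compound 3 `COC(=O)C1=C(C)NC(C)=C(C(=O)OCCc2ccccc2)C1c1csc(-c2ccc(Cl)cc2)n1` instead differs from compound 1 by benzyl in place of phenyl on a saturated chain carbon bound to an oxygen next to a carbonyl group; in this assay compound 3 gives 10200 nM, which is a 6.4-fold lower number from compound 1 to compound 3 (0.80 log units; beyond the scatter). Compound 4 `CCOC(=O)C1=C(C)NC(C)=C(C(=O)OCCc2ccccc2)C1c1csc(-c2ccc(Cl)cc2)n1` differs from compound 3 by methyl in place of hydrogen on a saturated chain carbon bound to an oxygen next to a carbonyl group, the same change that turned compound 1 into compound 2, made at the same place. Since that change produced the step of a 20-fold lower number from compound 1 to compound 2 (1.30 log units; beyond the scatter), compound 4 is expected to show a comparable but somewhat smaller step, a 13-fold lower number from compound 3 to compound 4 (1.11 log units; beyond the scatter). Among the measured compounds shown here, only one earlier pair shows this change. The estimate for compound 4 in this assay is therefore 800 nM, with a plausible range from 250 nM to 2500 nM.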

Compound 4, half-maximal inhibitory concentration: 12100 nM
The estimate for compound 4 lay 15-fold (1.18 log units) below the measured number; the whole stated range lies below it.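

In this assay, methoxycarbonyl to ethoxycarbonyl on the core of compound 3 gives a 1.2-fold higher number from compound 3 to compound 4 (0.07 log units; within the scatter), so the step seen on the core of compound 1 did not carry over: the same change on two cores in this assay, a 20-fold lower number (1.30 log units; beyond the scatter) from compound 1 to compound 2 and a 1.2-fold higher number (0.07 log units; within the scatter) from compound 3 to compound 4, 23-fold (1.37 log units) apart, beyond the scatter of two such steps. The benzyl in place of phenyl change also turns in the opposite direction once the ethyl ester is present, giving a 3.7-fold higher number from compound 2 to compound 4 (0.57 log units; beyond the scatter): the same change on two cores in this assay, a 6.4-fold lower number (0.80 log units; beyond the scatter) from compound 1 to compound 3 and a 3.7-fold higher number (0.57 log units; beyond the scatter) from compound 2 to compound 4, 23-fold (1.37 log units) apart, beyond the scatter of two such steps. The two ester changes therefore cannot be treated as independent in these four compounds, though this does not show why they interact or whether the same holds elsewhere in the series. The compounds shown leave open how a longer chain on the first ester would behave on each core. They also leave open what an amine at the end of the second ester chain would do.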